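A few compounds are considered here, and "the series" means these few. Any claim that something is new, unique, unknown or untested is made for them only; others in the source may bear on it.

Compound 1 `O=C1/C(=C/c2cccnc2)CNC/C1=C\c1ccccc1F`: 8890 nM
Compound 2 `O=C1/C(=C/c2cccnc2)CN(S(=O)(=O)c2ccc(F)cc2)C/C1=C\c1ccccc1F`: 15300 nM

In a functional assay on QGY-7703 cells (Homo sapiens) for cytotoxicity, read by MTT assay, with a stated time of 24 h (on this read-out lower numbers stand for stronger inhibition and higher numbers for weaker inhibition), compound 2 gives 15300 nM, which lies within the usual scatter of repeated measurements of compound 1 at 8890 nM. Going by the values given here, these are the only two numbers available, so the two compounds cannot be told apart.

The next compound, compound 3 `N#Cc1ccc(S(=O)(=O)N2C/C(=C\c3cccnc3)C(=O)/C(=C/c3ccccc3F)C2)cc1`, differs from compound 2 in one place: cyano in place of fluoro on an aromatic carbon, para to a large group (cyano in place of fluoro on an aromatic carbon). In other words, 4-fluorophenyl becomes 4-cyanophenyl.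

Among the compounds with values here, no measured step makes this exact swap, so the evidence is only indirect. The nearest step puts (4-fluorophenyl)sulfonyl in place of hydrogen on the ring amine nitrogen, and it gave a 1.7-fold higher number from compound 1 to compound 2 (0.24 log units; within the scatter). Adding that whole group left the number within the scatter, so a smaller edit within the group is not expected to produce a clear shift in either direction.

The estimated change is a 1.2-fold lower number from compound 2 to compound 3 (0.07 log units; within the scatter), which means no step beyond the scatter is expected. For compound 3 the estimated value is 13000 nM, with an expected range of 5000 nM to 30000 nM.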

Compound 3, half-maximal inhibitory concentration: 15800 nM
The estimate for compound 3 lay 1.2-fold (0.08 log units) below the measured number; the range from low to high includes it.
By their numbers in this assay, from the lowest: compounds 1, 2 and 3 (each within the scatter of the next).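

In this assay, cyano in place of fluoro on the aromatic carbon, para to a large group, gives a 1.0-fold higher number from compound 2 to compound 3 (0.01 log units; within the scatter), so this one exchange on the aryl ring now has a direct reading, and it cannot be told apart from no change. The (4-cyanophenyl)sulfonyl group in place of hydrogen on the amine nitrogen in the ring gives a 1.8-fold higher number from compound 1 to compound 3 (0.25 log units; within the scatter), which makes a second sulfonyl group at that nitrogen that stays within the scatter of the unsubstituted compound. No measurement is at hand that could explain these results.

The compounds shown leave open whether a different group on that aromatic carbon, such as an amine or a carboxylic acid, would move the number beyond the scatter. They also leave open whether something other than a sulfonyl group on the ring nitrogen, such as a longer alkyl chain, would separate itself from compound 1, since so far no single change in this small set has produced a clear step in either direction.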